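Biaryl replacement in the sulfonylacetic acid series

The compounds below may be only part of what the source reports. "The series", "measured", "known", "first", "only" and "open" are said of these compounds alone.

Compound 2 `Cc1cccc(C)c1-c1cccc(COc2ccc(S(=O)(=O)CC(=O)O)cc2)c1` stands lowest in a functional assay on CHO cells for agonist activity at Free fatty acid receptor 1 (Homo sapiens), read by FLIPR and calcium flux (on this read-out higher numbers stand for an effect only at larger amounts of compound and lower numbers for an effect already at smaller amounts), giving 66.1 nM. For the measured compounds named here, compound 1 `Cc1cccc(C)c1-c1cccc(COc2ccc(SCC(=O)O)cc2)c1` gives 195 nM, and the step of a 3.0-fold lower number from compound 1 to compound 2 (0.47 log units; beyond the scatter) is the only change beyond the scatter. Compound 3 `COCCOc1cc(C)c(-c2cccc(COc3ccc(S(=O)(=O)CC(=O)O)cc3)c2)c(C)c1` gives 126 nM; the step of a 1.9-fold higher number from compound 2 to compound 3 (0.28 log units; within the scatter) stays within the scatter. Compound 4 `Cc1noc(C)c1-c1cccc(COc2ccc(S(=O)(=O)CC(=O)O)cc2)c1` differs from compound 2 by 3,5-dimethyl-1,2-oxazol-4-yl in place of 2,6-dimethylphenyl on an aromatic carbon. Going by the values given here, no measured step replaces this ring itself; the step from compound 2 to compound 3 only adds a group on it and stays within the scatter, so it offers a weak hint that the region tolerates alteration. The expected step of a 1.7-fold higher number from compound 2 to compound 4 (0.22 log units; within the scatter) is therefore taken as none beyond the scatter, with a wide range. Compound 4 is estimated at 110 nM, between 30 nM and 400 nM.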

Compound 4, half-maximal effective concentration: 269 nM
Estimate against measurement, compound 4: 2.4-fold (0.39 log units) below, and the stated range covers the measured number.
By their numbers in this assay, from the lowest: compounds 2, 3, 1 and 4 (each within the scatter of the next, the first and the last beyond it).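

In this assay, exchanging the ring itself gives a 4.1-fold higher number from compound 2 to compound 4 (0.61 log units; beyond the scatter) and so goes beyond the scatter, whereas adding 2-methoxyethoxy to the 2,6-dimethylphenyl ring stayed within it. The position therefore responds to the identity of the ring, at least in this single exchange. No measured evidence bears on why this step occurs.

Going by these compounds, how a pyridine ring or a 2,6-dichlorophenyl group would read at this position remains open. Also open, on these data alone, is whether the sulfonyl-for-sulfanyl step holds with 3,5-dimethyl-1,2-oxazol-4-yl in place.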